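This account rests on a few compounds, and the source may have more. Where it says the series, first, only, none or still open, it means among the compounds named here.

Working notes on the series. For the measured compounds named here, compound 2 `O=C(Nc1cc(C(F)(F)F)ccc1NC1CCCCC1)c1cccnc1` is the only member with a number in a functional assay on HL-60 cells (Homo sapiens) for cytotoxicity, read by MTT assay, with a stated time of 48 h; on this read-out lower numbers stand for stronger inhibition and higher numbers for weaker inhibition: in this assay compound 2 gives 48300 nM, a weak result. Compound 1 `O=C(Nc1cc(C(F)(F)F)ccc1N1CCCCC1)c1ccccc1` is reported in this assay only as "not active" (no number reported), with no number attached, so compound 2 stands alone among the numbered entries and no ranking can be drawn.

Compound 3 `O=C(Nc1cc(C(F)(F)F)ccc1NC1CCCCC1)c1ccccc1` is not yet measured. It differs from compound 2 by phenyl in place of pyridin-3-yl on a carbonyl carbon. Going by the values given here, no step between two measured compounds covers this change, so the size of the effect in this assay has to be guessed. Compound 2 is already weak, and the other benzoyl member, compound 1, carries no number at all. The expected step from compound 2 to compound 3 is a 1.6-fold higher number from compound 2 to compound 3 (0.19 log units; within the scatter), a move toward weaker inhibition, with a real chance that only a limit is returned. Compound 3 is expected to give about 75000 nM, within 30000 nM to 180000 nM.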

Compound 3, half-maximal inhibitory concentration: 34900 nM
Beside the measured number, compound 3's estimate is 2.1-fold (0.33 log units) above it, within the range that was stated.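

In this assay, phenyl in place of pyridin-3-yl on a carbonyl carbon gives a 1.4-fold lower number from compound 2 to compound 3 (0.14 log units; within the scatter), so the two compounds cannot be told apart and the ring nitrogen of pyridin-3-yl is not needed for the weak activity seen here. The benzoyl group also proves compatible with a numbered result: compound 3 gives a value (34900 nM), while compound 1, also a benzoyl member, is reported only as "not active" (no number reported) and so cannot be placed against it. No supporting evidence bears on this result.

From the compounds shown here alone, it remains open whether another group on this carbonyl carbon, such as pyridin-4-yl, 4-aminophenyl or 4-carboxyphenyl, would move the number beyond the usual scatter. Also open, going by these compounds, is how much of the gap between compound 1 and compound 3 a numbered result would show.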